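Swapping cyclopentyl for 4-hydroxybutyl on an adenosine receptor ligand

The compounds below may be only part of what the source reports. "The series", "measured", "known", "first", "only" and "open" are said of these compounds alone.

Measured so far:
compound 1 `COc1cccc(-c2cnc(N)nc2-c2ccccc2)c1`: > 80%
compound 2 `Clc1cccc(-c2cnc(NC3CCCC3)nc2-c2ccccc2)c1`: > 80%

The two measured compounds share a core and differ in the group on the amino nitrogen. In an assay on CHO cells for displacement of a labelled ligand from adenosine receptor A1 (Homo sapiens), read by scintillation counting, with a stated time of 1 h, tested at 1 uM (a lower number here means less inhibition, a higher number more inhibition at the concentration tested (going by the name of the read-out)), compound 1 gives > 80%; this is a limit of the assay, not a number. In this assay compound 2 gives > 80%, again a limit. Compound 2 therefore stands at the upper edge of what this assay reports, (the limit of > 80% in this assay, at which 2 of the 2 values shown sit), and the numbers give no way to separate it from compound 1.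

Compound 3 `OCCCCNc1ncc(-c2cccc(Cl)c2)c(-c2ccccc2)n1` has not yet been measured. It differs from compound 2 in one place: 4-hydroxybutyl in place of cyclopentyl on a nitrogen on an aromatic ring. Among the measured compounds shown here, no measured pair shows a change of this kind, so the size of the step is open. Compound 3 is expected to give 75% in this assay, with a range from 50% to 95%. The step of a number at least 5 percentage points lower from compound 2 to compound 3 (that floor lies within the scatter) is expected to be a small loss, likely within the scatter.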

Compound 3, a percentage reported as inhibition, at one concentration (the size of the read-out at that concentration, not a potency): > 80%
Compound 3 was reported as a limit; the forecaster's own chance of this, stated with the estimate: 40%; middle value at least 5 percentage points away from the limit.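

In this assay compound 3 gives > 80%, which is a limit of the assay and not a number. Compound 2 sits at the same limit, so the step between compound 2 and compound 3 cannot be read: the limit of > 80% in this assay, at which 3 of the 3 values shown sit.

The compounds shown leave open whether 4-hydroxybutyl in place of cyclopentyl changes the inhibition at all, and if so, by how much.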